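The source may hold more compounds than are shown below. What is called first, only, known or untested is meant among the compounds shown, and "the series" means these compounds.

Measured in a functional assay on A549 cells (Homo sapiens) for cytotoxicity, read by MTT assay, with a stated time of 48 h; a lower number here means a stronger inhibitor, a higher number a weaker inhibitor:
- Compound 1 `COc1ccc(/C=C/c2cc(OC)c(OC)c(OC)c2-c2ccccc2)cc1`: 36000 nM
- Compound 2 `COc1cc(/C=C/c2ccc(C)cc2)c(-c2ccccc2)c(OC)c1OC`: 54000 nM

Compound 2 cannot be separated from compound 1 on these numbers, as the two values lie within the scatter of each other. The next compound, compound 3 `C=C(c1ccc(Cl)cc1)c1cc(OC)c(OC)c(OC)c1-c1ccccc1`, differs from compound 2 as follows: 1-(4-chlorophenyl)ethenyl in place of 2-(4-methylphenyl)ethenyl on an aromatic carbon. This places 1-(4-chlorophenyl)ethenyl in place of 2-(4-methylphenyl)ethenyl, para to a methoxy group.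

For the measured compounds named here, only one measured step bears on this change, and only in part: a 1.5-fold higher number from compound 1 to compound 2 (0.18 log units; within the scatter), for methyl in place of methoxy. Going by the values given here, no measured compound carries chlorine or a 1-(4-chlorophenyl)ethenyl group, so the data indicate no direction. Among the compounds with values here, with that small step as the only guide, no change beyond the scatter is expected in this assay.

The expected step is a 1.4-fold lower number from compound 2 to compound 3 (0.13 log units; within the scatter). For compound 3 the estimated value is 40000 nM, within a range of 12000 nM to 90000 nM.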

Compound 3, half-maximal inhibitory concentration: 40000 nM
The estimate for compound 3 equals the measured number at the digits printed, within the range that was stated.
By their numbers in this assay, from the lowest: compounds 1, 3 and 2 (each within the scatter of the next).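

In this assay the step from a 2-(4-methylphenyl)ethenyl group to a 1-(4-chlorophenyl)ethenyl group gives a 1.4-fold lower number from compound 2 to compound 3 (0.13 log units; within the scatter) and stays within the scatter. The earlier step had only exchanged methoxy for methyl on an aromatic carbon, whereas this one replaces the whole group para to a methoxy group and brings in chlorine, yet no difference can be read from the numbers. No evidence is at hand that accounts for this result.

Chlorine and the altered ethenyl attachment enter together, so the compounds shown cannot separate what each contributes. As far as these compounds go, it also remains open whether an amine or a carboxylic acid on the aromatic ring of this group would move the number beyond the scatter.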